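The source may hold more compounds than are shown below. What is called first, only, known or untested is meant among the compounds shown, and "the series" means these compounds.

Measured so far in a physicochemical assay for lipophilicity, using the shake flask method; on this read-out lower numbers stand for lower lipophilicity and higher numbers for higher lipophilicity:
compound 1, `C[C@H](Oc1ccc2ncc(/C=C/S(=O)(=O)O)c(C3CC3)c2c1)c1c(Cl)ccc(F)c1Cl`, 2.5
compound 2, `C[C@H](Oc1ccc2ncc(/C=C/C(N)=O)c(C3CC3)c2c1)c1c(Cl)ccc(F)c1Cl`, reported as a limit, > 5.5

Compound 2 stands at the upper end of this assay; its reading > 5.5 is a limit, not a number. Compound 1 gives 2.5 in this assay. Going by the values given here, the single measured step, a number at least 3.00 log units higher from compound 1 to compound 2 (beyond the scatter), is bounded by the limit of > 5.5 in this assay, at which 1 of the 2 values shown sits, so its full size is open.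

Compound 3 is `C[C@H](Oc1ccc2ncc(/C=C/C(=O)N3CC[C@@H](N)[C@H](C(=O)O)C3)c(C3CC3)c2c1)c1c(Cl)ccc(F)c1Cl`. (a group of 10 heavy atoms (6 carbon, 2 nitrogen, 2 oxygen; one six-membered non-aromatic ring with 1 hetero atom) in place of one nitrogen atom, on a carbonyl carbon). Among the compounds with values here, this change sits on the same carbonyl carbon as the measured step but brings in a different group, so the measured step shows only that exchanges at this position can move this assay by a large amount, in either direction. A large downward step from compound 2 is expected, though its size is uncertain since compound 2 is a limit. The step expected is a number at least 2.50 log units lower from compound 2 to compound 3 (beyond the scatter). Compound 3 is estimated at 3, between 1.5 and 4.5.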

Compound 3, distribution coefficient: 3.1
Compound 3: middle estimate off by 0.10 log units, on the low side; the range from low to high includes it.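

With the amino on the carbonyl carbon exchanged for the ring-bearing group of compound 3, the step of a number at least 2.40 log units lower from compound 2 to compound 3 (beyond the scatter) shows that in this assay a carbonyl-linked group at this position need not stay at the top of the scale. The step of a number 0.60 log units higher from compound 1 to compound 3 (beyond the scatter) is modest, so a group without sulfo can give a reading not far from that of compound 1. From the compounds shown here alone, compound 2 is reported as a limit, not a number, and so the full size of the first step stays open: the limit of > 5.5 in this assay, at which 1 of the 3 values shown sits.

The compounds shown do not separate what the amine, the carboxylic acid and the six-membered ring of compound 3 each contribute. The same ring bearing only the amine or only the carboxylic acid, or a longer open chain on the same carbonyl carbon, would address this.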